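Moving the Ring Nitrogen: Estimate for Compound 4

The source may hold more compounds than are shown below. What is called first, only, known or untested is meant among the compounds shown, and "the series" means these compounds.

In an ADME assay on HepG2 2.2.15 cells (Homo sapiens) for cytotoxicity (a lower number here means a stronger inhibitor, a higher number a weaker inhibitor), the three measured compounds give these numbers:
Compound 2 `O=C1CCCC2=C1C(c1ccc(F)cc1Cl)N=C(c1cccnc1)N2`: 82800 nM
Compound 1 `O=C1CCCC2=C1C(c1ccc(F)cc1Cl)N=C(c1cnccn1)N2`: 777000 nM
Compound 3 `O=C1CCCC2=C1C(c1ccccc1Cl)N=C(c1cccnc1)N2`: 1120000 nM

Compound 2 stands lowest of the three, and both of its neighbours lie beyond the scatter: compound 1 sits a 9.4-fold lower number from compound 1 to compound 2 (0.97 log units; beyond the scatter) away, compound 3 further still at a 14-fold higher number from compound 2 to compound 3 (1.13 log units; beyond the scatter). The unmeasured compound 4 `O=C1CCCC2=C1C(c1ccc(F)cc1Cl)N=C(c1ccncc1)N2` keeps the 2-chloro-4-fluorophenyl group and changes only the ring on the carbon with a double bond to nitrogen: pyridin-4-yl in place of pyridin-3-yl on a carbon with a double bond to nitrogen.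

Of the two measured steps, only the first bears on this change, since it too swaps the aromatic ring at that same carbon; the second alters the fluoro group elsewhere and says nothing about this position. The step of a 9.4-fold lower number from compound 1 to compound 2 (0.97 log units; beyond the scatter) shows that the choice of six-membered aromatic ring here moves the number beyond the scatter, yet that step also changed the count of ring nitrogen atoms, which the present change does not. A step in this assay of modest size is therefore expected, most likely toward a higher number, though a result within the scatter would not surprise.

Compound 4 is expected to give 160000 nM, within a range of 40000 nM to 650000 nM, a step of a 1.9-fold higher number from compound 2 to compound 4 (0.29 log units; within the scatter).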

Compound 4, half-maximal inhibitory concentration: 142000 nM
For compound 4 the middle estimate is 1.1-fold (0.05 log units) above the measured one, within the range that was stated.
By their numbers in this assay, from the lowest: compounds 2 and 4 (each within the scatter of the next); then compounds 1 and 3 (each within the scatter of the next).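

In this assay the step of a 1.7-fold higher number from compound 2 to compound 4 (0.23 log units; within the scatter) shows that pyridin-4-yl and pyridin-3-yl cannot be told apart at this carbon, so among these two groups the place of the ring nitrogen makes no difference that this read-out can resolve. The step of a 5.5-fold lower number from compound 1 to compound 4 (0.74 log units; beyond the scatter) lies beyond the scatter and runs the same way as the step of a 9.4-fold lower number from compound 1 to compound 2 (0.97 log units; beyond the scatter) so in these three compounds, which all carry the 2-chloro-4-fluorophenyl group, both pyridinyl groups stand apart from pyrazin-2-yl. No measurement at hand gives a reason for these numbers.

The compounds shown leave open how a plain phenyl ring, a pyridin-2-yl group, or a pyridine ring carrying an amine or a methoxy group would read at this same carbon. They also leave open whether replacing fluoro with hydrogen on the aromatic ring would give a step as large as a 14-fold higher number from compound 2 to compound 3 (1.13 log units; beyond the scatter) when pyridin-4-yl is present, since that change is shown only with pyridin-3-yl.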